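A few compounds are considered here, and "the series" means these few. Any claim that something is new, unique, unknown or untested is made for them only; others in the source may bear on it.

In a functional assay on KYSE-410 cells (Homo sapiens) for antiproliferative activity, read by MTT assay, with a stated time of 72 h (a higher number here means a weaker inhibitor, a lower number a stronger inhibitor), compound 1 `COc1ccc(-c2ccc3c(C(=O)Nc4cccc(F)c4)cc(=O)[nH]c3c2)cc1` gives 18000 nM. Compound 2 `Cc1ccc(-c2ccc3c(C(=O)Nc4cccc(F)c4)cc(=O)[nH]c3c2)cc1` reads > 20000 nM, which is a limit of the assay and not a number. Its standing in the series is therefore known only as that limit.

Compound 3 `Cc1cc(-c2ccc3c(C(=O)Nc4cccc(F)c4)cc(=O)[nH]c3c2)c(C)cc1F` has 4-fluoro-2,5-dimethylphenyl in place of 4-methylphenyl on an aromatic carbon. Among the measured compounds shown here, the only measured step, an at least 1.1-fold higher number from compound 1 to compound 2 (0.04 log units; that floor lies within the scatter), is methyl in place of methoxy on an aromatic carbon. For the measured compounds named here, it is the sole guide here and does not involve the fluorine or the extra methyl now entering. On that step, no change beyond the scatter is expected in this assay, and no direction can be supported. The expected step is a number no higher from compound 2 to compound 3 (the limit leaves the size open). For compound 3 the estimated value is 20000 nM, with an expected range of 8000 nM to 40000 nM.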

Compound 3, half-maximal inhibitory concentration: > 20000 nM
Compound 3 ended at the assay's limit; the forecaster's own chance of this, stated with the estimate: 55%; the middle value lies on the limit itself.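

Compound 3 reads > 20000 nM in this assay, which is a limit of the assay and not a number, so the steps that rest on two limits cannot be read. Among the compounds shown here, the one readable step at this position is an at least 1.1-fold higher number from compound 1 to compound 3 (0.04 log units; that floor lies within the scatter), and it comes with 4-fluoro-2,5-dimethylphenyl in place of 4-methoxyphenyl. The fluorine and the extra methyl thus bring no reading inside the range of the assay, and the series now rests mostly on a limit: the limit of > 20000 nM in this assay, at which 2 of the 3 values shown sit.

From the compounds shown here alone, how far compound 2 and compound 3 actually lie beyond that limit stays open, and with it any ranking of the two. Also open is how an amine or a carboxylic acid on this phenyl ring would read, since all the groups shown here carry only methyl, methoxy or fluorine.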